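The source may hold more compounds than are shown below. What is called first, only, known or untested is meant among the compounds shown, and "the series" means these compounds.

Three analogues share one core. Compound 1 `CCS(=O)(=O)Nc1cc(-c2ccc3ncnc(Nc4cccc(F)c4)c3c2)cnc1OC` gives 8020 nM in a functional assay on MCF7 cells (Homo sapiens) for cytotoxicity, read by sulforhodamine B assay, with a stated time of 72 h; a higher number here means a weaker inhibitor, a lower number a stronger inhibitor; compound 2 `CCS(=O)(=O)Nc1cc(-c2ccc3ncnc(Nc4ccc(OC(F)(F)F)cc4)c3c2)cnc1OC` gives 23700 nM, the highest of the three; compound 3 `CCS(=O)(=O)Nc1cc(-c2ccc3ncnc(Nc4ccc(OC)cc4)c3c2)cnc1OC` gives 1790 nM. Compound 2 sits a 3.0-fold higher number from compound 1 to compound 2 (0.47 log units; beyond the scatter) and a 13-fold lower number from compound 2 to compound 3 (1.12 log units; beyond the scatter). Compound 4 `CCS(=O)(=O)Nc1cc(-c2ccc3ncnc(Nc4ccc(C(=O)OC)c(OC)c4)c3c2)cnc1OC` is not yet measured; it carries 3-methoxy-4-(methoxycarbonyl)phenyl in place of 4-(trifluoromethoxy)phenyl on a nitrogen on an aromatic ring. Both steps at this nitrogen, a 3.0-fold higher number from compound 1 to compound 2 (0.47 log units; beyond the scatter) and a 4.5-fold lower number from compound 1 to compound 3 (0.65 log units; beyond the scatter), moved the number beyond the scatter, so a step is expected here as well, most likely downward, since every other group tried in this place gave a lower number than that of compound 2. The step is estimated as a 3.4-fold lower number from compound 2 to compound 4 (0.53 log units; beyond the scatter), and compound 4 is expected near 7000 nM, within 1800 nM to 28000 nM.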

Compound 4, half-maximal inhibitory concentration: 10900 nM
Estimate against measurement, compound 4: 1.6-fold (0.19 log units) below; low and high end bracket the measured number.
By their numbers in this assay, from the lowest: compound 3; then compounds 1 and 4 (each within the scatter of the next); then compound 2.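

In this assay 3-methoxy-4-(methoxycarbonyl)phenyl on this nitrogen gives back only part of what 4-(trifluoromethoxy)phenyl lost (a 2.2-fold lower number from compound 2 to compound 4 (0.34 log units; beyond the scatter)) and falls short of 4-methoxyphenyl (a 6.1-fold higher number from compound 3 to compound 4 (0.78 log units; beyond the scatter)). This ring with two groups stands level with 3-fluorophenyl (a 1.4-fold higher number from compound 1 to compound 4 (0.13 log units; within the scatter)), so the methoxy in its name does not bring the number of compound 3. No measurement here bears on why these numbers differ. Which of the two groups in compound 4 sets its number stays open, as does the effect of a carboxylic acid or an amine in place of the methoxycarbonyl.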